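From Diethylamino to Carboxy: Expecting the Half-Life of Compound 3

The compounds below may be only part of what the source reports. "The series", "measured", "known", "first", "only" and "open" are said of these compounds alone.

- Compound 1 `O=C(/C=C/CF)Nc1ccccc1` gives > 8.53 h (a limit of the assay, not a number)
- Compound 2 `CCN(CC)C/C=C/C(=O)Nc1ccccc1` gives 2.83 h (a measured number)

Within the data shown here, both results come from an ADME assay for pharmacokinetics, read by LC-MS, in phosphate buffer, with a stated time of 120 min, at pH 7.4, tested at 1 uM, in the presence of a further agent that is not named here (on this read-out lower numbers stand for a shorter-lived compound and higher numbers for a longer-lived compound), and compound 2 holds the only actual number of the pair, at 2.83 h in that read-out. Compound 3 `O=C(O)C/C=C/C(=O)Nc1ccccc1` has not yet been measured. Its difference from compound 2 is carboxy in place of diethylamino on a saturated chain carbon bound to a double-bonded chain carbon with carboxy in place of diethylamino on a saturated chain carbon bound to a double-bonded chain carbon.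

Among the measured compounds shown here, one measured step bears on this change, as it concerns the same place: an at least 3.0-fold lower number from compound 1 to compound 2 (0.47 log units; beyond the scatter) with diethylamino in place of fluoro. That step is beyond the scatter, and its true size is open on one side. Going by that step, the loss of diethylamino in compound 3 is expected to bring a higher number in this assay even though carboxy is not fluoro. The expected change is a 2.5-fold higher number from compound 2 to compound 3 (0.39 log units; beyond the scatter) and this estimate is a modest rise. For compound 3 the estimated half-life is 7 h with an expected range from 3 h to 15 h in this read-out.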

Compound 3, half-life: > 8.53 h
Compound 3 was reported as a limit; the forecaster's own chance of this, stated with the estimate: 35%; middle value at least 1.2-fold (0.08 log units) away from the limit.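

Carboxy at this saturated chain carbon bound to a double-bonded chain carbon gives an at least 3.0-fold higher number from compound 2 to compound 3 (0.47 log units; beyond the scatter) in this assay and so shows that the shorter half-life of compound 2 is not seen only against fluoro. Compound 3 gives > 8.53 h as a limit of the assay and not as a number. Among the three groups shown at this place, diethylamino alone gives a measured number, while the step between compound 1 and compound 3 cannot be read, and fluoro and carboxy cannot be put in any order: the limit of > 8.53 h in this assay, at which 2 of the 3 values shown sit.

On these data alone, how far compound 1 and compound 3 lie beyond that limit remains open, so the full size of the difference from diethylamino is unknown. As far as these compounds go, it is also open whether the shorter half-life belongs to diethylamino in particular or would also appear with a smaller amine such as dimethylamino, a cyclic amine such as morpholine, or a longer chain carrying the same amine.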